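This account rests on a few compounds, and the source may have more. Where it says the series, first, only, none or still open, it means among the compounds named here.

Three members of the series have a number in a functional assay on the whole organism (strain NMRI) with Mus musculus as the target, with a stated time of 4 h; a higher number here means that more compound is needed for the effect, a lower number that less compound is needed. Compound 1 `Cc1ccc(-c2nc3ccc(Br)cn3c2/C=N/OCc2cn(Cc3ccc(C#N)cc3)nn2)cc1` gives 40 mg/kg. Compound 2 `Cc1ccc(Cn2cc(CO/N=C/c3c(-c4ccc(F)cc4)nc4ccc(Br)cn34)nn2)cc1` gives 100 mg/kg, and compound 3 `Cc1ccc(Cn2cc(CO/N=C/c3c(-c4ccc(C)cc4)nc4ccc(Br)cn34)nn2)cc1` gives 100 mg/kg. On these numbers compound 2 is level with compound 3 at the digits printed, the two together standing at the highest of the three values, and the step of no change at the digits printed from compound 2 to compound 3 (within the scatter) sits within the scatter. Compound 1 is the one set apart: the step of a 2.5-fold higher number from compound 1 to compound 3 (0.40 log units; beyond the scatter) is modest but beyond the scatter.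

Compound 4 `N#Cc1ccc(Cn2cc(CO/N=C/c3c(-c4ccc(F)cc4)nc4ccc(Br)cn34)nn2)cc1` is not yet measured. Against compound 2 it differs in one place: cyano in place of methyl on an aromatic carbon. That is, 4-methylbenzyl goes to 4-cyanobenzyl.

Of the measured steps, the one that bears directly is the step from compound 1 to compound 3, which is the same exchange run the other way, on a partner that differs elsewhere on the shared core; the step from compound 2 to compound 3 shows that this other difference left the number unchanged within the scatter. Reversing the exchange is therefore expected to lower the number by about the same size, as step a 2.5-fold lower number from compound 2 to compound 4 (0.40 log units; beyond the scatter). For compound 4 the estimate is 40 mg/kg, with a range of 20 mg/kg to 80 mg/kg.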

Compound 4, minimum effective dose: 100 mg/kg
The estimate for compound 4 lay 2.5-fold (0.40 log units) below the measured number; the measured number lies above the stated range.
By their numbers in this assay, from the lowest: compound 1; then compounds 2, 3 and 4 (each within the scatter of the next).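

In this assay, cyano in place of methyl at this place, on the aromatic ring of the benzyl group, gives no change at the digits printed from compound 2 to compound 4 (within the scatter), so the exchange between 4-methylbenzyl and 4-cyanobenzyl does not have one fixed size across the two partners. The earlier reading of that exchange was a 2.5-fold higher number from compound 1 to compound 3 (0.40 log units; beyond the scatter), yet the difference between the two readings is too small to count as a real dependence on the partner: the same change on two cores in this assay, a 2.5-fold higher number (0.40 log units; beyond the scatter) from compound 1 to compound 3 and no change at the digits printed (within the scatter) from compound 4 to compound 2, 2.5-fold (0.40 log units) apart, within the scatter of two such steps. The exchange between fluoro and methyl on the other aromatic ring reads the same way, with a 2.5-fold higher number from compound 1 to compound 4 (0.40 log units; beyond the scatter) and no change at the digits printed from compound 2 to compound 3 (within the scatter), which leaves compound 1 set apart as the only pairing of 4-cyanobenzyl with that methyl, though this pairing effect is no firmer than the gap allows: the same change on two cores in this assay, no change at the digits printed (within the scatter) from compound 2 to compound 3 and a 2.5-fold lower number (0.40 log units; beyond the scatter) from compound 4 to compound 1, 2.5-fold (0.40 log units) apart, within the scatter of two such steps.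

The compounds shown leave open whether a group other than methyl or cyano at this place, such as an amine or a carboxylic acid, would move the number on either partner. Among the compounds shown here, with compound 1 the only member at 40 mg/kg, it also stays unsettled whether that lower number belongs to the pairing or to compound 1 alone.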